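Compound 2 to compound 4: a fluoro step

This account rests on a few compounds, and the source may have more. Where it says the series, first, only, none or still open, it means among the compounds named here.

In a functional assay on MDA-MB-231 cells (Homo sapiens) for antiproliferative activity, read by MTT assay, with a stated time of 72 h (a higher number here means a weaker inhibitor, a lower number a stronger inhibitor), compound 2 (`COc1cc(CCc2ccccc2)cc(OC)c1O`) gives > 25000 nM, which is a limit and not a number. Compound 1 (`COc1cc(CCc2ccccn2)cc(OC)c1O`) gives > 25000 nM, also a limit. Compound 3 (`COc1cc(CCc2ccc(F)cc2)cc(OC)c1O`) gives > 25000 nM, again a limit. Among the compounds with values here, the whole series so far sits at the limit of > 25000 nM in this assay, at which 3 of the 3 values shown sit.

Compound 4 (`COc1cc(CCc2ccccc2F)cc(OC)c1O`) differs from compound 2 by fluoro in place of hydrogen on an aromatic carbon, ortho to a large group. Within the data shown here, two measured steps bear on it: a step that the two limits leave unreadable from compound 2 to compound 3, the same kind of exchange, and a step that the two limits leave unreadable from compound 1 to compound 2. Neither has a readable size, so no step beyond the scatter is expected in this assay. The expected step is a step that the limit leaves unreadable from compound 2 to compound 4. The estimate for compound 4 is 30000 nM, with an expected range of 12000 nM to 80000 nM.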

Compound 4, half-maximal inhibitory concentration: 9220 nM
The estimate for compound 4 lay 3.3-fold (0.51 log units) above the measured number, outside the stated range (below it).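

In this assay, within the data shown here, fluoro ortho to a large group gives the only readable number so far, with an at least 2.7-fold lower number from compound 2 to compound 4 (0.43 log units; beyond the scatter). Compound 3 carries fluoro at another place on the same ring, and compound 3 stays at a limit, > 25000 nM. The steps among compounds 1, 2 and 3 cannot be read, so the place of the fluoro matters in this pair, while the rest of the series stays unresolved: the limit of > 25000 nM in this assay, at which 3 of the 4 values shown sit.

Whether this step belongs to fluoro itself stays open, as chloro, methyl or methoxy at the same place are not among the compounds shown. Also open, as far as these compounds go, is whether the step would hold with a longer chain in the shared core.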